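The source may report more compounds than this note shows. Statements on the series, on what has been measured and on what is new or still open speak of the compounds shown alone.

Among the measured compounds shown here, compound 2 `CCCCNc1nc(N)nc2ccc(F)cc12` gives 0.1 uM in an ADME assay on HEK293 cells for agonist activity at Toll-like receptor 8 (Homo sapiens), read by a luciferase reporter, with a stated time of 6 h (a higher number here means that more compound is needed for the effect, a lower number that less compound is needed), the lowest of the two numbers measured so far. Its nearest neighbour is compound 1 `CCNc1nc(N)nc2ccccc12`, and in this assay compound 1 gives 0.77 uM, a gap beyond the usual scatter. Compound 3 `CCCCNc1nc(N)nc2ccc(CO)cc12` has not yet been measured; it differs from compound 2 by hydroxymethyl in place of fluoro on an aromatic carbon. For the measured compounds named here, no pair of measured compounds shares a single change, so the size of this step is a matter of expectation alone. Compound 3 is expected to give 0.3 uM in this assay, within 0.1 uM to 1 uM. The expected step is a 3.0-fold higher number from compound 2 to compound 3 (0.48 log units; beyond the scatter), a modest shift toward needing more compound, near the edge of the scatter.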

Compound 3, minimum effective concentration: 0.2 uM
Beside the measured number, compound 3's estimate is 1.5-fold (0.18 log units) above it; measured number inside the range.
By their numbers in this assay, from the lowest: compounds 2 and 3 (each within the scatter of the next); then compound 1.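

Among the compounds shown here, putting hydroxymethyl in place of fluoro on this aromatic carbon gives a 2.0-fold higher number from compound 2 to compound 3 (0.30 log units; within the scatter) in this assay and is the only single change that can be read here. At this position, the larger group, with its hydrogen-bond donor and acceptor, leaves compound 3 indistinguishable from compound 2. Nothing available explains this outcome. As far as these compounds go, whether an amine, a carboxylic acid or a longer chain on the same carbon would also stay within the scatter remains open. So does whether a carbon bearing hydroxymethyl would behave alike with a different chain on the shared core.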